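Thiazolidinedione amides on MCF7 growth: a heteroaryl swap

This account rests on a few compounds, and the source may have more. Where it says the series, first, only, none or still open, it means among the compounds named here.

Measured so far:
compound 1 `Cc1cnc(NC(=O)COc2ccc(/C=C3\SC(=O)NC3=O)cc2)s1`: < 100000 nM
compound 2 `O=C(COc1ccc(/C=C2\SC(=O)NC2=O)cc1)Nc1ncc([N+](=O)[O-])s1`: < 100000 nM

In a functional assay on MCF7 cells (Homo sapiens) for cytotoxicity, read by sulforhodamine B assay, with a stated time of 48 h (on this read-out higher numbers stand for weaker inhibition of growth and lower numbers for stronger inhibition of growth), compound 2 gives < 100000 nM, which is a limit of the assay and not a number. In this assay compound 1 likewise gives < 100000 nM, again a limit rather than a number. For the measured compounds named here, the one measured step, a step that the two limits leave unreadable from compound 1 to compound 2, is therefore not readable, and the only evidence is the limit of < 100000 nM in this assay, at which 2 of the 2 values shown sit. So compound 2 stands at a limit, with no scale on which it can be placed against compound 1.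

Compound 3 `O=C(COc1ccc(/C=C2\SC(=O)NC2=O)cc1)Nc1ccccn1` differs from compound 2 by pyridin-2-yl in place of 5-nitro-1,3-thiazol-2-yl on an amide-type nitrogen. Going by the values given here, no measured step bears readably on this change. The expectation for compound 3 is therefore no more than that it also stays in the range of the two limits already seen, which means a step from compound 2 of a step that the limit leaves unreadable from compound 2 to compound 3 is expected. Compound 3 is estimated at 30000 nM, in a range from 5000 nM to 100000 nM.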

Compound 3, concentration for 50% growth inhibition: 29500 nM
Compound 3: middle estimate off by 1.0-fold (0.01 log units), on the high side; measured number inside the range.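

For the compounds shown here, compound 3 gives a number in this assay, but no step from compound 1 or compound 2 to compound 3 can be read, since those two compounds rest on a limit: the limit of < 100000 nM in this assay, at which 2 of the 3 values shown sit. The compounds shown leave open whether pyridin-2-yl, 5-methyl-1,3-thiazol-2-yl or 5-nitro-1,3-thiazol-2-yl on the amide-type nitrogen makes any difference to growth inhibition.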